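Methyl on the pyridyl: compound 3 to compound 4

This account rests on a few compounds, and the source may have more. Where it says the series, first, only, none or still open, it means among the compounds named here.

Of the compounds shown here, three have been measured on the shared core, with its structure given beside each. Compound 1 `CC(Nc1ncnc(N)c1C#N)c1nc2ccc(F)cc2c(O)c1-c1ccccc1` carries a hydroxyl on the core and a phenyl ring. In an assay on isolated protein for inhibition of phosphatidylinositol 4,5-bisphosphate 3-kinase catalytic subunit beta isoform (Homo sapiens), read by AlphaScreen (on this read-out lower numbers stand for stronger inhibition and higher numbers for weaker inhibition), compound 1 gives > 20000 nM, which is a limit of the assay and not a number. Compound 2 `CC(Nc1ncnc(N)c1C#N)c1nc2ccc(F)cc2cc1-c1ccccn1` carries a pyridin-2-yl in place of the phenyl. In this assay compound 2 gives > 20000 nM, again a limit. For the measured compounds named here, compound 3 `C[C@H](Nc1ncnc(N)c1C#N)c1nc2ccc(F)cc2c(-c2ccccn2)c1-c1ccccn1` carries two pyridin-2-yl rings; in this assay compound 3 gives 2800 nM, the only numerical value in the set. Compound 3 therefore stands apart from the two others, which sit at the limit of > 20000 nM in this assay, at which 2 of the 3 values shown sit.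

Compound 4 `Cc1cccnc1-c1c(-c2ccccn2)c([C@H](C)Nc2ncnc(N)c2C#N)nc2ccc(F)cc12` differs from compound 3 in one place: methyl in place of hydrogen on an aromatic carbon. Going by the values given here, no measured pair covers a change of this kind, so the step is expected to be modest, of about the size of the scatter or a little beyond it, with slight gain as the more likely direction. The step from compound 3 to compound 4 is estimated as a 1.6-fold lower number from compound 3 to compound 4 (0.19 log units; within the scatter). In this assay compound 4 is expected to give 1800 nM, with a range from 500 nM to 7000 nM.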

Compound 4, half-maximal inhibitory concentration: > 20000 nM
Compound 4 was reported as a limit; the forecaster's own chance of this, stated with the estimate: 5%; at least 11-fold (1.04 log units) between middle value and limit.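

In this assay compound 4 gives > 20000 nM, which is a limit of the assay and not a number. This position on the pyridyl ring, ortho to a large group and two atoms from the ring nitrogen, is therefore not indifferent to substitution: going from pyridin-2-yl to 3-methylpyridin-2-yl gives an at least 7.1-fold higher number from compound 3 to compound 4 (0.85 log units; beyond the scatter), so one added carbon is enough to lose the measurable value. Compound 3 is now the only compound of the four with a numerical value: the limit of > 20000 nM in this assay, at which 3 of the 4 values shown sit.

From the compounds shown here alone, the full size of the step stays unknown, as only its lower bound can be read. Going by these compounds, whether fluorine, methoxy or an amine on this aromatic carbon would keep a measurable value, and whether a methyl on another carbon of this ring would do so, remains open.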